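The source may hold more compounds than are shown below. What is called first, only, known or untested is meant among the compounds shown, and "the series" means these compounds.

For the measured compounds named here, in a functional assay on A549 cells (Homo sapiens) for inhibition, read by sulforhodamine B assay, with a stated time of 48 h (a lower number here means a stronger inhibitor of growth, a higher number a weaker inhibitor of growth), compound 1 `c1ccc(-c2nc3ncccn3c2CN2CCCC2)cc1` gives 50 nM and holds the lowest of the three numbers so far. Compound 2 `c1ccc(-c2nc3ncccn3c2CN2CCCCC2)cc1` stands at 260 nM and compound 3 `Cc1ccn2c(CN3CCCC3)c(-c3ccccc3)nc2n1` stands at 4150 nM on the same scale. Piperidin-1-yl in place of pyrrolidin-1-yl brings a 5.2-fold higher number from compound 1 to compound 2 (0.72 log units; beyond the scatter) and methyl in place of hydrogen on an aromatic carbon brings an 83-fold higher number from compound 1 to compound 3 (1.92 log units; beyond the scatter) in the same direction.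

Compound 4 `c1csc(-c2nc3ncccn3c2CN2CCCC2)c1` has not been measured yet. Going by the values given here, it keeps the rest of compound 1 but carries thiophen-2-yl in place of phenyl on an aromatic carbon as its single change. Neither measured step touches this group, so both guide the expectation only loosely. They do show that one small edit to compound 1 can move the number a long way. With a 5.2-fold higher number from compound 1 to compound 2 (0.72 log units; beyond the scatter) as the smaller of the two moves, a modest rise rather than a fall is expected in this assay for this change. The expected step is a 2.2-fold higher number from compound 1 to compound 4 (0.34 log units; beyond the scatter) and is only an estimate. Compound 4 is estimated at 110 nM with a likely range from 30 nM to 450 nM as the expected outcome.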

Compound 4, concentration for 50% growth inhibition: 180 nM
Compound 4: middle estimate off by 1.6-fold (0.21 log units), on the low side; measured number inside the range.
By their numbers in this assay, from the lowest: compound 1; then compounds 4 and 2 (each within the scatter of the next); then compound 3.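

In this assay, the place on the five-membered aromatic ring with 2 nitrogen that bears the phenyl group now proves sensitive to what sits there: thiophen-2-yl in place of phenyl gives a 3.6-fold higher number from compound 1 to compound 4 (0.56 log units; beyond the scatter). For the compounds shown here, the earlier steps changed the saturated amine ring or added a methyl elsewhere, so this is the first view of this place, and it shows that even one aromatic ring swapped for another moves the number beyond the scatter. Nothing measured on these two groups accounts for the rise.

With only one replacement for phenyl shown, it remains open whether a group such as 4-fluorophenyl or pyridin-3-yl would hold or lower the number here. On these data alone, it also remains open whether thiophen-2-yl would give a similar step alongside piperidin-1-yl.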